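The compounds below may be only part of what the source reports. "The series", "measured", "known", "first", "only" and "open" are said of these compounds alone.

The account follows one step in a physicochemical assay for solubility, in phosphate buffer, at pH 7.4; on this read-out lower numbers stand for lower solubility and higher numbers for higher solubility. Compound 1 `COc1ccccc1C(=O)NC(=O)Nc1ccc(-c2ccccn2)c(C(F)(F)F)c1` gives 19 ug/mL in this assay. Compound 2 `COc1ccccc1C(=O)NC(=O)Nc1ccc(-c2nccs2)c(C(F)(F)F)c1` returns only a limit in this assay, namely < 1 ug/mL, as recorded in the limit of < 1 ug/mL in this assay, at which 1 of the 2 values shown sits. Among the compounds with values here, the shift between those two, an at least 19-fold lower number from compound 1 to compound 2 (1.27 log units; beyond the scatter), is the sole measured step on which the next one can lean. Compound 3 `COc1ccccc1C(=O)NC(=O)Nc1ccc(-c2ccccc2)c(C(F)(F)F)c1` differs from compound 2 as follows: phenyl in place of 1,3-thiazol-2-yl on an aromatic carbon. The measured step also exchanged one aromatic ring for another on the same aromatic carbon, so it sets the scale of what such a swap can do in this assay, though it does not fix the direction for this new ring. Compound 3 is therefore expected to remain near or under the limit of this assay, the expected step being a step that the limit leaves unreadable from compound 2 to compound 3. Compound 3 is estimated at 0.5 ug/mL in this assay, within a range from 0.1 ug/mL to 3 ug/mL.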

Compound 3, solubility: < 1 ug/mL
Compound 3: a limit, no number (the forecaster's own chance of this, stated with the estimate: 70%); the middle value does not contradict the limit.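

In this assay compound 3 gives < 1 ug/mL, which is a limit of the assay and not a number. On this aromatic carbon, pyridin-2-yl now stands apart from two different rings, 1,3-thiazol-2-yl and phenyl, with phenyl giving an at least 19-fold lower number from compound 1 to compound 3 (1.27 log units; beyond the scatter). The step between compound 2 and compound 3 cannot be read, so these two rings cannot be ordered, and the values shown now gather at one limit: the limit of < 1 ug/mL in this assay, at which 2 of the 3 values shown sit.

Going by these compounds, how far under that limit compound 2 and compound 3 actually lie stays open. On these data alone, compound 1 gives 19 ug/mL, and whether this higher value belongs to pyridin-2-yl alone or extends to other rings also stays open. As far as these compounds go, whether an amine such as morpholine on this aromatic carbon would give a readable number in this assay also remains open.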